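Swapping a Methyl-Oxadiazole for a Thiophene on a Shared Core

The compounds below may be only part of what the source reports. "The series", "measured", "known", "first", "only" and "open" are said of these compounds alone.

Measured compounds:
- Compound 1, `O=C(O)c1ccc(C(=O)C2=C(O)C(=O)N(c3ccc(-c4ccon4)cc3)C2C2CCCCC2)cc1`, gives 0.008 in an ADME assay on the whole organism (serum, Rattus norvegicus) for protein binding; on this read-out higher numbers stand for a larger free fraction and lower numbers for a smaller free fraction.
- Compound 2, `COc1ccc(C(=O)C2=C(O)C(=O)N(c3ccc(-c4ccon4)cc3)C2c2ccccc2OCCO)cc1`, gives 0.003 in this assay.
- Compound 3, `Cc1nc(-c2ccc(N3C(=O)C(O)=C(C(=O)C(C)(C)C)C3c3ccccc3OCCO)cc2)no1`, gives "not determined" (no result reported) in this assay.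

Compound 3 thus stands nowhere on the numbers shown: for it no unbound fraction is known. Its two measured relatives, compound 1 and compound 2, both sit at very small unbound fractions, so the shared core appears to be held tightly by serum proteins in both cases.

Compound 4, `CC(C)(C)C(=O)C1=C(O)C(=O)N(c2ccc(-c3ccsc3)cc2)C1c1ccccc1OCCO`, differs from compound 3 in one place: thiophen-3-yl in place of 5-methyl-1,2,4-oxadiazol-3-yl on an aromatic carbon. Among the measured compounds shown here, no step between measured compounds shows what such a swap does to the unbound fraction, and compound 3 itself has no number to step from. The expectation therefore rests only on compound 1 and compound 2, whose values suggest that compounds of this core keep a small free fraction. The step from compound 3 to compound 4 is expected to stay within the usual scatter, in no clear direction.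

Compound 4 is estimated at 0.003, with a range from 0.001 to 0.01.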

Compound 4, unbound fraction: 0.002
Compound 4: middle estimate off by 1.5-fold (0.18 log units), on the high side; low and high end bracket the measured number.
By their numbers in this assay, from the lowest: compounds 4 and 2 (each within the scatter of the next); then compound 1.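

No step can be read from compound 3 to compound 4: in this assay compound 3 has no number, while compound 4 gives 0.002. Nothing shown accounts for this value. On these data alone, what replacing 5-methyl-1,2,4-oxadiazol-3-yl with thiophen-3-yl does to the free fraction remains open.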